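Moving the ring nitrogen on the carbonyl-linked pyridine

This account rests on a few compounds, and the source may have more. Where it says the series, first, only, none or still open, it means among the compounds named here.

Of the compounds shown here, three have numbers so far. Compound 1 `CC(C)(C)C(=O)N1N=CCC1c1cccc(Cl)c1` gives 6.6 in a physicochemical assay for lipophilicity, read by HPLC, measured as chromatographic lipophilicity, at pH 7.4 (a lower number here means a more polar compound, a higher number a more lipophilic compound), and compound 3 `CC(C)(C)C(=O)n1nccc1-c1ccccc1` gives 8.3 in this assay. Compound 2 `O=C(c1ccccn1)N1N=CCC1c1ccccc1` stands lowest of the three with 2.4 in this assay; compound 1 is nearest to it and compound 3 furthest, both gaps beyond the scatter.

Compound 4 `O=C(c1ccncc1)N1N=CCC1c1ccccc1` has not been measured. It differs from compound 2 in one place only: pyridin-4-yl in place of pyridin-2-yl on a carbonyl carbon. Among the compounds with values here, no measured pair shows this change, so its size is unknown from the data. The expectation is for no step beyond the scatter in this assay, leaning slightly lower; the estimated step is a number 0.10 log units lower from compound 2 to compound 4 (within the scatter). Compound 4 is therefore expected to give 2.3 in this assay, within a range of 1.8 to 2.8.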

Compound 4, distribution coefficient: 2.7
The estimate for compound 4 lay 0.40 log units below the measured number; measured number inside the range.
By their numbers in this assay, from the lowest: compounds 2 and 4 (each within the scatter of the next); then compound 1; then compound 3.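

In this assay the first single-place change readable in this series is a number 0.30 log units higher from compound 2 to compound 4 (within the scatter) for pyridin-4-yl in place of pyridin-2-yl on a carbonyl carbon. On this carbonyl carbon the two pyridines are therefore not told apart by this measurement, on the evidence of this single pair. Nothing available explains this result.

From the compounds shown here alone, whether pyridin-3-yl at the same place would also stay within the scatter remains open. So does whether a carboxylic acid or an amine on the pyridine ring would produce a step beyond it.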